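The source may hold more compounds than are shown below. What is called first, only, known or untested is meant among the compounds shown, and "the series" means these compounds.

Of the compounds shown here, three have been measured in a functional assay on HCT-116 cells (Homo sapiens) for cytotoxicity, with a stated time of 3 days (a lower number here means a stronger inhibitor, a higher number a weaker inhibitor), and none of them gives a number. Compound 1, `C#Cc1ncccn1`, reaches only the limit of > 40000 nM in this assay. Compound 3, `CC#CC1=Nc2ccccc2C(C)(C)O1`, likewise stops at the limit of > 40000 nM. Compound 2, `Ic1nc2ccccc2o1`, the starting point of the step followed here, also sits at the limit of > 40000 nM. So compound 2 stands nowhere in particular on the numbers shown: what is known of it is a limit alone, shared with the other two, as the limit of > 40000 nM in this assay, at which 3 of the 3 values shown sit, sums up. Among the measured compounds shown here, no step between two measured compounds can be drawn from such data, so there is no measured yardstick for how much a change of one group shifts the result in this assay.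

The change from compound 2 to compound 4, `C#Cc1nc2ccccc2o1`, is ethynyl in place of iodo on an aromatic carbon. The data show nothing about what an ethynyl in place of an iodo does to this readout. For the measured compounds named here, every value so far is a limit. The expected step is therefore a number no higher from compound 2 to compound 4 (the limit leaves the size open), nothing beyond the scatter, with the result most likely reported again as a limit. Compound 4 is accordingly expected to give about 40000 nM in this assay, within a range from 15000 nM to 120000 nM.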

Compound 4, half-maximal inhibitory concentration: 11600 nM
Beside the measured number, compound 4's estimate is 3.4-fold (0.54 log units) above it; the measured number lies below the stated range.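

Among the compounds shown here, replacing iodo with ethynyl on this aromatic carbon, next to the ring nitrogen and next to the ring oxygen, gives the first step that can be read in this assay: an at least 3.4-fold lower number from compound 2 to compound 4 (0.53 log units; beyond the scatter). Compound 2 gives > 40000 nM, which is a limit and not a number, so the step gives only a minimum size and the real gap could be larger. Compound 4 is also the only compound here to give a number at all, showing that a change at this one position can bring a compound out of the limit that holds the others: the limit of > 40000 nM in this assay, at which 3 of the 4 values shown sit.

The compounds shown compare only iodo and ethynyl at this position on the shared core, so they cannot tell whether ethynyl is special or whether many other groups would give a similar number, and they do not explain why the number falls. An amine, a nitrile or a longer chain in the same place would show how much the outcome depends on the group that sits there.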